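This account rests on a few compounds, and the source may have more. Where it says the series, first, only, none or still open, it means among the compounds named here.

Measured in a functional assay on MCF7 cells (Homo sapiens) for antiproliferative activity, read by MTT assay, with a stated time of 72 h; a lower number here means a stronger inhibitor, a higher number a weaker inhibitor:
- Compound 1 `CCCCCc1ccc(-c2cn(C/C=C3\OC(=O)C(OCc4ccccc4)=C3OCc3ccccc3)nn2)cc1`: > 100000 nM, a limit of the assay.
- Compound 2 `COc1ccccc1-c1cn(C[C@H](O)[C@H]2OC(=O)C(OCc3ccccc3)=C2OCc2ccccc2)nn1`: > 100000 nM, a limit of the assay.
- Compound 3 `COc1ccc(-c2cn(C/C=C3\OC(=O)C(OCc4ccccc4)=C3OCc3ccccc3)nn2)cc1`: 39100 nM.

Among the compounds with values here, compound 2 gives only a limit, so no step from it can be sized exactly. Most of the series stands at the same point: the limit of > 100000 nM in this assay, at which 2 of the 3 values shown sit.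

The next compound, compound 4 `O=C1O[C@H]([C@@H](O)Cn2cc(CCCCl)nn2)C(OCc2ccccc2)=C1OCc1ccccc1`, carries 3-chloropropyl in place of 2-methoxyphenyl on an aromatic carbon of the five-membered aromatic ring with 3 nitrogen: 3-chloropropyl in place of 2-methoxyphenyl on an aromatic carbon.

Within the data shown here, only one measured step is available, an at least 2.5-fold lower number from compound 1 to compound 3 (0.40 log units; beyond the scatter). It bears on this change only loosely: it swaps a group on a six-membered aromatic ring that compound 4 lacks, and the core of compound 1 differs from that of compound 2. No size can be carried over from it, so in this assay only a small step is expected, with its direction open and a result close to the limit of compound 2 the likeliest outcome.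

The estimated change is an at least 1.2-fold lower number from compound 2 to compound 4 (0.09 log units; that floor lies within the scatter). Compound 4 is expected at 80000 nM, with an estimated range of 25000 nM to 200000 nM.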

Compound 4, half-maximal inhibitory concentration: 24500 nM
Compound 4: the middle estimate sits 3.3-fold (0.51 log units) above what was measured; measured number outside the range, below it.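

Replacing the aryl group on this core gives an at least 4.0-fold lower number from compound 2 to compound 4 (0.61 log units; beyond the scatter) in this assay, so the group on the aromatic carbon of the five-membered aromatic ring with 3 nitrogen can bring a compound of this core off the limit. The earlier step only exchanged a group on a six-membered aromatic ring, whereas this change removes that ring altogether, and compound 4 shows that a ring at this place is not required for a measurable value. Compound 2 gives only a limit, so this size is a floor and not an exact step.

Whether the chlorine or the chain itself accounts for the step stays open, and plain propyl, 3-aminopropyl or a longer chloroalkyl chain at this place would separate the two. Much of the comparison still rests on a single bound: the limit of > 100000 nM in this assay, at which 2 of the 4 values shown sit.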